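The compounds below may be only part of what the source reports. "The series", "measured", "known", "first", "only" and "open" are said of these compounds alone.

Measured compounds in a functional assay on HeLa cells (Homo sapiens) for cytotoxicity, read by MTT assay, with a stated time of 72 h; on this read-out higher numbers stand for weaker inhibition and lower numbers for stronger inhibition:

Compound 1, `CC(=O)N(/N=N/c1ccc([N+](=O)[O-])cc1Cl)c1ccc([N+](=O)[O-])cc1Cl`, gives 630 nM.
Compound 2, `O=C(c1ccccc1F)N(/N=N/c1ccc([N+](=O)[O-])cc1Cl)c1ccc([N+](=O)[O-])cc1Cl`, gives 2350 nM.
Compound 3, `O=C(c1ccccc1C(F)(F)F)N(/N=N/c1ccc([N+](=O)[O-])cc1Cl)c1ccc([N+](=O)[O-])cc1Cl`, gives 10600 nM.

Compound 3 stands highest of the three numbers in this assay. Its nearest neighbour is compound 2, through the step of a 4.5-fold higher number from compound 2 to compound 3 (0.65 log units; beyond the scatter); furthest is compound 1, through the step of a 17-fold higher number from compound 1 to compound 3 (1.23 log units; beyond the scatter). The remaining step, a 3.7-fold higher number from compound 1 to compound 2 (0.57 log units; beyond the scatter), also runs upward.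

Compound 4, `O=C(c1cccc(C(F)(F)F)c1)N(/N=N/c1ccc([N+](=O)[O-])cc1Cl)c1ccc([N+](=O)[O-])cc1Cl`, is not yet measured. It differs from compound 3 in one place: 3-(trifluoromethyl)phenyl in place of 2-(trifluoromethyl)phenyl on a carbonyl carbon. The two share every atom and differ only in where the trifluoromethyl sits on the phenyl.

Within the data shown here, none of the measured steps moves a group from one ring position to another. The steps from compound 1 exchange methyl for an aryl group on the carbonyl carbon, and the step from compound 2 to compound 3 exchanges fluoro for trifluoromethyl on an aromatic carbon; neither speaks to a positional shift of the same group. The series gives no basis for a direction. The expectation for compound 4 is therefore a number close to that of compound 3, with a step of a 1.3-fold lower number from compound 3 to compound 4 (0.12 log units; within the scatter) that may fall within the scatter, and a wide range to cover either direction. Compound 4 is estimated at 8000 nM, between 2500 nM and 25000 nM.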

Compound 4, half-maximal inhibitory concentration: 1180 nM
For compound 4 the middle estimate is 6.8-fold (0.83 log units) above the measured one, outside the stated range (below it).
By their numbers in this assay, from the lowest: compounds 1, 4 and 2 (each within the scatter of the next, the first and the last beyond it); then compound 3.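

In this assay, among these compounds, the place of the trifluoromethyl on the phenyl matters by itself: with the same atoms joined differently, 3-(trifluoromethyl)phenyl in place of 2-(trifluoromethyl)phenyl on the carbonyl carbon gives a 9.0-fold lower number from compound 3 to compound 4 (0.95 log units; beyond the scatter), a kind of change that no earlier pair covered. An aryl group on the carbonyl carbon therefore does not always carry a higher number than methyl, and neither does trifluoromethyl compared with fluoro: a 1.9-fold higher number from compound 1 to compound 4 (0.27 log units; within the scatter) and a 2.0-fold lower number from compound 2 to compound 4 (0.30 log units; within the scatter) both lie within the scatter, whereas a 17-fold higher number from compound 1 to compound 3 (1.23 log units; beyond the scatter) stands beyond it, so that step belongs to 2-(trifluoromethyl)phenyl and not to every trifluoromethyl-bearing aryl group, while compound 2 still stands beyond the scatter from compound 1. No measurement at hand offers an explanation for the effect of this shift.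

The compounds shown do not tell whether moving the fluoro of compound 2 on its phenyl would produce a similar step. They also leave open whether an amine or a carboxylic acid in place of the trifluoromethyl of compound 4 would keep its number in this assay.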